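Replacing the fluorophenyl urea in a vasopressin receptor agonist series

The source may report more compounds than this note shows. Statements on the series, on what has been measured and on what is new or still open speak of the compounds shown alone.

Measured compounds:
compound 1 `Cc1cc(C(=O)N2CCCCc3ccccc32)ccc1CNC(=O)Nc1ccccc1F` — 30 nM
compound 2 `Cc1cc(C(=O)N2CCCCc3ccccc32)ccc1CNC(=O)NCC(=O)N1CCCC1` — 100 nM
compound 3 `Cc1cc(C(=O)N2CCCCc3ccccc32)ccc1CNC(=O)N1CCC[C@H]1C(=O)O` — 680 nM

In a functional assay on HEK293 cells for agonist activity at Vasopressin V2 receptor (Homo sapiens), read by a luciferase reporter and cAMP accumulation (a higher number here means that more compound is needed for the effect, a lower number that less compound is needed), compound 1 gives 30 nM and stands lowest of the three numbers; compound 2 lies nearest at a 3.3-fold higher number from compound 1 to compound 2 (0.52 log units; beyond the scatter), and compound 3 furthest at a 23-fold higher number from compound 1 to compound 3 (1.36 log units; beyond the scatter). Compound 4 `Cc1cc(C(=O)N2CCCCc3ccccc32)ccc1CNC(=O)N1C[C@H](O)C[C@H]1C(=O)N(C)C` has not yet been measured. It differs from compound 1 as follows: 2-(dimethylcarbamoyl)-4-hydroxypyrrolidin-1-yl in place of (2-fluorophenyl)amino on a carbonyl carbon.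

Among the compounds with values here, two measured steps bear on this change. The step of a 23-fold higher number from compound 1 to compound 3 (1.36 log units; beyond the scatter) puts a pyrrolidine-based group on the same carbonyl carbon, though with a carboxylic acid rather than the dimethylcarbamoyl and hydroxy groups of compound 4. The step of a 3.3-fold higher number from compound 1 to compound 2 (0.52 log units; beyond the scatter) puts a pyrrolidine amide on the urea nitrogen and costs less. Compound 4 carries the ring directly on the carbonyl carbon as in compound 3 but without the acid, so a loss somewhere between those two steps is expected. For compound 4 a step of a 5.0-fold higher number from compound 1 to compound 4 (0.70 log units; beyond the scatter) is therefore estimated, and its value is expected to be 150 nM, with a range from 50 nM to 500 nM.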

Compound 4, half-maximal effective concentration: 2.3 nM
Estimate against measurement, compound 4: 65-fold (1.81 log units) above; the whole stated range lies above it.
By their numbers in this assay, from the lowest: compound 4; then compound 1; then compound 2; then compound 3.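

The result shows that the aromatic ring of the (2-fluorophenyl)amino group is not needed for a low number at this carbonyl carbon, as the non-aromatic 2-(dimethylcarbamoyl)-4-hydroxypyrrolidin-1-yl goes beyond it (a 13-fold lower number from compound 1 to compound 4 (1.12 log units; beyond the scatter)). A pyrrolidine ring bonded directly to the carbonyl carbon therefore does not itself bring the loss seen with 2-carboxypyrrolidin-1-yl (a 300-fold lower number from compound 3 to compound 4 (2.47 log units; beyond the scatter)). The substituted ring also goes well beyond the (((pyrrolidin-1-yl)carbonyl)methyl)amino group (a 43-fold lower number from compound 2 to compound 4 (1.64 log units; beyond the scatter)).

From the compounds shown here alone, the hydroxy and dimethylcarbamoyl groups enter together, so their separate shares remain open, as does the reading of a primary amide or a methyl ether in their place, or of the other stereoisomers. Nothing shown here accounts for the size of the gain.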